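Lengthening the ester tether on a sulfur-linked side chain

A few compounds are considered here, and "the series" means these few. Any claim that something is new, unique, unknown or untested is made for them only; others in the source may bear on it.

Compound 1 `CCOC(=O)Sc1nc2cc(-n3nc(C(C)(C)C)sc3=O)c(F)cc2s1`: 40 nM
Compound 2 `CCCOC(=O)CSc1nc2cc(-n3nc(C(C)(C)C)sc3=O)c(F)cc2s1`: 1310 nM
Compound 3 `CCOC(=O)CCSc1nc2cc(-n3nc(C(C)(C)C)sc3=O)c(F)cc2s1`: 9260 nM

Three compounds sharing one core differ only in the group carried on the sulfur. In an assay on isolated protein for inhibition of protoporphyrinogen oxidase (Homo sapiens), read by capillary electrophoresis (on this read-out higher numbers stand for weaker inhibition and lower numbers for stronger inhibition), compound 3 gives 9260 nM, the highest of the three numbers; compound 2 gives 1310 nM and compound 1 gives 40 nM. Compound 4 `CCOC(=O)CCCSc1nc2cc(-n3nc(C(C)(C)C)sc3=O)c(F)cc2s1` is not yet measured. It differs from compound 3 by (ethoxycarbonyl)methyl in place of ethoxycarbonyl on a saturated chain carbon, two bonds along the chain from a sulfur.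

Among the measured compounds shown here, two measured steps bear on this change. The step from compound 1 to compound 2 a 33-fold higher number from compound 1 to compound 2 (1.52 log units; beyond the scatter) and that from compound 1 to compound 3 a 230-fold higher number from compound 1 to compound 3 (2.36 log units; beyond the scatter) both show that moving the ester further from the sulfur raises the number in this assay, and the step from compound 2 to compound 3 a 7.1-fold higher number from compound 2 to compound 3 (0.85 log units; beyond the scatter) shows a smaller rise for the second extension. For compound 4 a further rise in this assay is expected, of modest size a 3.2-fold higher number from compound 3 to compound 4 (0.51 log units; beyond the scatter). Compound 4 is therefore estimated at 30000 nM, within the range 8000 nM to 110000 nM.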

Compound 4, inhibition constant: 8670 nM
Estimate against measurement, compound 4: 3.5-fold (0.54 log units) above; low and high end bracket the measured number.
By their numbers in this assay, from the lowest: compound 1; then compound 2; then compounds 4 and 3 (each within the scatter of the next).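

In this assay the added chain carbon of compound 4 brings no further rise: the change gives a 1.1-fold lower number from compound 3 to compound 4 (0.03 log units; within the scatter) and so 3-(ethoxycarbonyl)propyl and 2-(ethoxycarbonyl)ethyl on the sulfur cannot be told apart here. Among the compounds shown here, the climb seen across the earlier compounds therefore stops at compound 3, and a 6.6-fold higher number from compound 2 to compound 4 (0.82 log units; beyond the scatter) and a 220-fold higher number from compound 1 to compound 4 (2.34 log units; beyond the scatter) stand close to the steps those two compounds already showed to compound 3. Going past 2-(ethoxycarbonyl)ethyl thus changes nothing further on this read-out, while the number stays far from that of compound 1.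

As far as these compounds go, whether a longer chain still, or a free carboxylic acid or an amide in place of the ethyl ester, would stay on this flat stretch remains open. Nothing available here accounts for the numbers ceasing to rise at this chain length.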